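The source may hold more compounds than are shown below. What is called first, only, known or untested is meant among the compounds shown, and "the series" means these compounds.

Compound 1 `CN(C)CC[C@H](CSc1ccccc1)Nc1ccc(S(=O)(=O)NC(=O)c2ccc(N3CCN(Cc4ccccc4-c4ccc(Cl)cc4)CC3)cc2)cc1C(F)(F)F` gives < 1 nM, which is a limit of the assay and not a number.
Compound 2 `CN(C)CC[C@H](CSc1ccccc1)Nc1ccc(S(=O)(=O)NC(=O)c2ccc(N3CCN(Cc4ccccc4-c4ccc(Cl)cc4)CC3)cc2)cc1S(C)(=O)=O` gives < 1 nM, again a limit and not a number.
Compound 3 `CN(C)CC[C@H](CSc1ccccc1)Nc1ccc(S(=O)(=O)NC(=O)c2ccc(N3CCN(Cc4ccccc4-c4ccc(Cl)cc4)CC3)cc2)cc1` gives 14 nM.

Within the data shown here, in an assay on isolated protein for displacement of a labelled ligand from Bcl2-associated agonist of cell death (Homo sapiens), read by fluorescence polarization (on this read-out lower numbers stand for stronger inhibition and higher numbers for weaker inhibition), compound 3 therefore stands as the only compound of the three with an actual number; the other two values sit at the limit of < 1 nM in this assay, at which 2 of the 3 values shown sit. Compound 4 `CN(C)CC[C@H](CSc1ccccc1)Nc1ccc(S(=O)(=O)NC(=O)c2ccc(N3CCN(Cc4ccccc4-c4ccc(Cl)cc4)CC3)cc2)cc1S(=O)(=O)C(F)(F)F` has not yet been measured. It differs from compound 3 by (trifluoromethyl)sulfonyl in place of hydrogen on an aromatic carbon. Among the measured compounds shown here, two measured steps bear on this change, both running in the opposite direction: an at least 14-fold higher number from compound 1 to compound 3 (1.14 log units; beyond the scatter), where hydrogen replaced trifluoromethyl on that aromatic carbon, and an at least 14-fold higher number from compound 2 to compound 3 (1.14 log units; beyond the scatter), where hydrogen replaced methylsulfonyl on the same carbon. The step that the two limits leave unreadable from compound 1 to compound 2 cannot be read, so the two substituents cannot be ranked against each other. Since both substituents went with much lower numbers than hydrogen in compound 1 and compound 2, a sizeable drop is expected for the (trifluoromethyl)sulfonyl group in compound 4, estimated as a 28-fold lower number from compound 3 to compound 4 (1.45 log units; beyond the scatter), with a good chance that only a limit is reported. The expected value for compound 4 in this assay is 0.5 nM, within a range from 0.1 nM to 3 nM.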

Compound 4, inhibition constant: < 1 nM
Compound 4 gave a limit, no number; the forecaster's own chance of this, stated with the estimate: 70%; the middle value lies beyond the limit too.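

In this assay, (trifluoromethyl)sulfonyl on this aromatic carbon, ortho to a large group, gives an at least 14-fold lower number from compound 3 to compound 4 (1.14 log units; beyond the scatter), so a third group now joins trifluoromethyl and methylsulfonyl in sitting far from hydrogen, and none of the compounds shown goes against this. Compound 4 gives < 1 nM, which is a limit of the assay and not a number. The steps among compound 1, compound 2 and compound 4, including trifluoromethyl in place of methyl on the sulfonyl sulfur, cannot be read, because all three compounds stop at the same point: the limit of < 1 nM in this assay, at which 3 of the 4 values shown sit.

Going by these compounds, whether these three groups differ from one another at all therefore stays open, and only values that are actual numbers could order them. Also open is how far the low values extend to other kinds of group on this carbon, such as an amine, a carboxylic acid or a single chlorine atom, since every group shown so far other than hydrogen is either trifluoromethyl or a sulfonyl group.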